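Benzyl for 2-bromophenyl on the amine nitrogen

The source may report more compounds than this note shows. Statements on the series, on what has been measured and on what is new or still open speak of the compounds shown alone.

Compound 3 `O=C(C1=C(Nc2ccccc2Br)C(=O)N(CCCn2ccnc2)C1c1ccc(Br)cc1)c1ccccc1` stands second highest of the three numbers in a functional assay on NCI-H1299 cells (Homo sapiens) for antiproliferative activity, read by MTT assay, with a stated time of 72 h (a lower number here means a stronger inhibitor, a higher number a weaker inhibitor), where compound 3 gives 15600 nM. Its nearest neighbour is compound 2 `O=C(C1=C(Nc2ccccc2)C(=O)N(CCCn2ccnc2)C1c1ccc(Br)cc1)c1ccccc1`, which gives 21200 nM in this assay; the step of a 1.4-fold lower number from compound 2 to compound 3 (0.13 log units; within the scatter) lies within the scatter. Compound 1 `CCCCCOC1=C(C(=O)c2ccccc2)C(c2ccc(Br)cc2)N(CCCn2ccnc2)C1=O` gives 10300 nM in this assay, and the step of a 1.5-fold higher number from compound 1 to compound 3 (0.18 log units; within the scatter) is likewise within the scatter. Among the measured compounds shown here, the only step read as beyond the scatter is a 2.1-fold higher number from compound 1 to compound 2 (0.31 log units; beyond the scatter).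

Compound 4 `O=C(C1=C(NCc2ccccc2)C(=O)N(CCCn2ccnc2)C1c1ccc(Br)cc1)c1ccccc1` differs from compound 3 by benzyl in place of 2-bromophenyl on an amine nitrogen. For the measured compounds named here, no measured pair exchanges 2-bromophenyl for benzyl on this nitrogen; the pairs that bear on the site are the pentyloxy-to-anilino exchanges and the bromo-for-hydrogen step, all of them small. The three measured numbers fall in a narrow band, with only a 2.1-fold higher number from compound 1 to compound 2 (0.31 log units; beyond the scatter) reaching beyond the scatter. A step of that order at most is therefore expected for compound 4, in either direction, and more likely none beyond the scatter. The expected step of a 1.0-fold lower number from compound 3 to compound 4 (0.02 log units; within the scatter) is accordingly close to nil. Compound 4 is estimated at 15000 nM, within a range of 6000 nM to 40000 nM.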

Compound 4, half-maximal inhibitory concentration: 25300 nM
Compound 4: middle estimate off by 1.7-fold (0.23 log units), on the low side, within the range that was stated.
By their numbers in this assay, from the lowest: compounds 1, 3, 2 and 4 (each within the scatter of the next, the first and the last beyond it).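

In this assay, the amine nitrogen accepts benzyl in place of 2-bromophenyl (a 1.6-fold higher number from compound 3 to compound 4 (0.21 log units; within the scatter)) and benzyl in place of phenyl (a 1.2-fold higher number from compound 2 to compound 4 (0.08 log units; within the scatter)) with no readable change, so among the groups shown, neither the bromo substituent nor the change from phenyl to benzyl separates these compounds. Benzylamino in place of pentyloxy on the double-bonded ring carbon gives a modest step (a 2.5-fold higher number from compound 1 to compound 4 (0.39 log units; beyond the scatter)), which joins the anilino exchange as a second step beyond the scatter, while compound 3 goes against any general reading of amine-linked groups as weaker than pentyloxy (a 1.5-fold higher number from compound 1 to compound 3 (0.18 log units; within the scatter)). Nothing measured on hand accounts for these small differences.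

Going by these compounds, it remains open whether a longer chain ending in a carboxylic acid or in a morpholine on the amine nitrogen would move the number beyond the scatter of compound 3. Also open, on these data alone, is what a hydroxyl or an unsubstituted amine would give in place of pentyloxy on the double-bonded ring carbon.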